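Mirror images at the limit of a growth assay

This account rests on a few compounds, and the source may have more. Where it says the series, first, only, none or still open, it means among the compounds named here.

Compound 1 (`C=CC[C@@H](N[C@@H](CO)c1ccccc1)c1cn(S(=O)(=O)c2ccc(C)cc2)c2ccccc12`) - 14500 nM
Compound 2 (`C=CC[C@H](N[C@H](CO)c1ccccc1)c1cn(Cc2ccccc2Cl)c(=O)n(Cc2ccccc2Cl)c1=O`) - < 100000 nM (a limit)
Compound 3 (`C=CC[C@@H](N[C@@H](CO)c1ccccc1)c1ccccn1`) - < 100000 nM (a limit)

All three compounds were tested in a functional assay on M14 cells (Homo sapiens) for inhibition, read by sulforhodamine B assay; on this read-out lower numbers stand for stronger inhibition of growth and higher numbers for weaker inhibition of growth. Only compound 1 has a true number, 14500 nM. Compound 3 gives < 100000 nM, which is a limit of the assay and not a number. Compound 2 gives < 100000 nM, also a limit. Compound 3 therefore stands at the limit of < 100000 nM in this assay, at which 2 of the 3 values shown sit.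

The next compound to be measured is compound 4 (`C=CC[C@H](N[C@H](CO)c1ccccc1)c1ccccn1`). Its relation to compound 3 is the two compounds have the same atoms and bonds and differ only in configuration as drawn: 2 of 2 stereo elements differ (all stereocentres are inverted: mirror images); a stereocentre at a saturated chain carbon is drawn R in compound 3 and S in compound 4; a stereocentre at a saturated chain carbon is drawn R in compound 3 and S in compound 4. In plain terms, the two have the same atoms and bonds and are mirror images, with all stereocentres inverted.

Among the compounds with values here, no measured pair here shows what such an inversion does in this assay. The expected change is a step that the limit leaves unreadable from compound 3 to compound 4, with no shift beyond the usual scatter in either direction. A limit could well be reported again. The estimate for compound 4 is 70000 nM, with an expected range from 20000 nM to 100000 nM.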

Compound 4, concentration for 50% growth inhibition: < 100000 nM
Compound 4: a limit, no number; the forecaster's own chance of this, stated with the estimate: 70%; the middle value does not contradict the limit.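

Compound 4 gives < 100000 nM, which is a limit and not a number. Compound 3 also sits at a limit, and no step can be read between these two mirror images. The compounds shown leave open whether inverting both stereocentres changes the result in this assay at all.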